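Bromo to fluoro on the anilino ring: lipophilicity note

This account rests on a few compounds, and the source may have more. Where it says the series, first, only, none or still open, it means among the compounds named here.

Measured so far:
compound 1, `Fc1ccc(NC(=S)N/N=C/c2ccc(Oc3ccc(Br)cc3)cc2)cc1`: 5.88
compound 2, `Fc1ccc(Oc2ccc(/C=N/NC(=S)Nc3ccc(Br)cc3)cc2)cc1`: 5.82
compound 3, `O=[N+]([O-])c1ccc(Oc2ccc(/C=N/NC(=S)Nc3ccc(Br)cc3)cc2)cc1`: 5.68

All three values come from a physicochemical assay for lipophilicity, in phosphate buffer, measured as octanol-water partition, with a stated time of 24 h; a higher number here means a more lipophilic compound, a lower number a more polar compound. Compound 2 stands second of the three numbers measured in this assay, with compound 1 giving 5.88 and compound 3 giving 5.68; both gaps to compound 2 lie within the scatter, so no order among the three can be read from them. Among the compounds with values here, the one step fully covered by measurement is a number 0.14 log units lower from compound 2 to compound 3 (within the scatter), which itself is within the scatter.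

Compound 4, `Fc1ccc(NC(=S)N/N=C/c2ccc(Oc3ccc(F)cc3)cc2)cc1`, has not yet been measured in this assay. Relative to compound 2 the change is fluoro in place of bromo on an aromatic carbon. Within the data shown here, no measured pair in this set exchanges bromo for fluoro; the step from compound 2 to compound 3 concerns a different exchange and gives no direct guide. The expectation therefore rests on the change alone, with the step from compound 2 to compound 4 in this assay expected to be a drop beyond the scatter, a number 0.67 log units lower from compound 2 to compound 4 (beyond the scatter). Compound 4 is estimated at 5.15 in this assay, with a range from 4.75 to 5.55.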

Compound 4, partition coefficient: 5.19
Compound 4: the middle estimate sits 0.04 log units below what was measured; low and high end bracket the measured number.
By their numbers in this assay, from the lowest: compound 4; then compounds 3, 2 and 1 (each within the scatter of the next).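

In this assay the exchange of bromo for fluoro gives the first readable movement in this series, and it does so at two places: a number 0.63 log units lower from compound 2 to compound 4 (beyond the scatter) for the change from (4-bromophenyl)amino to (4-fluorophenyl)amino, and a number 0.69 log units lower from compound 1 to compound 4 (beyond the scatter) for the exchange on the other aromatic ring of the core. Within the data shown here, the only earlier step, nitro in place of fluoro, gave a number 0.14 log units lower from compound 2 to compound 3 (within the scatter) and so showed no readable effect at its position, whereas the bromo position responds to the exchange on either ring, in the same direction and beyond the scatter. The data shown offer no measurement that explains why these numbers fall with this exchange.

Still open, from the compounds shown here alone, is where chloro, methyl or methoxy at the same aromatic carbon would fall relative to the bromo and fluoro compounds, which would show whether the step follows the halogen alone or holds for other small groups. Also open, going by these compounds, is how far the number would move with a more strongly ionisable group at that place, such as an amine or a carboxylic acid, or with a longer chain.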